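A New Benzyl Arm for Compound 2

The compounds below may be only part of what the source reports. "The series", "measured", "known", "first", "only" and "open" are said of these compounds alone.

In a functional assay on Huh-7 cells (Homo sapiens) for antiproliferative activity, read by sulforhodamine B assay, with a stated time of 72 h (a higher number here means a weaker inhibitor, a lower number a stronger inhibitor), compound 2 `N#Cc1cccc(COc2ccc(-c3cc(CN4CCN(Cc5ccc(C(F)(F)F)cc5)CC4)no3)cc2)c1` gives 100 nM, the lowest of the three measured numbers. Compound 3 `N#Cc1ccc(COc2ccc(-c3cc(CN4CCN(Cc5ccc(C(F)(F)F)cc5)CC4)no3)cc2)cc1` gives 1000 nM and compound 1 `N#Cc1ccccc1COc1ccc(-c2cc(CN3CCN(Cc4ccc(C(F)(F)F)cc4)CC3)no2)cc1` gives 5000 nM. The steps of a 50-fold lower number from compound 1 to compound 2 (1.70 log units; beyond the scatter), a 10-fold higher number from compound 2 to compound 3 (1.00 log units; beyond the scatter) and a 5.0-fold lower number from compound 1 to compound 3 (0.70 log units; beyond the scatter) all change the cyanophenyl on the saturated chain carbon bound to an oxygen on an aromatic ring. Compound 4 `N#Cc1cccc(COc2ccc(-c3cc(CN4CCN(Cc5ccccc5F)CC4)no3)cc2)c1` keeps that part and instead carries 2-fluorophenyl in place of 4-(trifluoromethyl)phenyl on a saturated chain carbon bound to an amine nitrogen in a ring. Going by the values given here, none of the measured steps touches this position, and no measured pair differs there, leaving no direct guide to its size or direction. A change of modest size is expected, with wide uncertainty. The expected step is a 3.0-fold higher number from compound 2 to compound 4 (0.48 log units; beyond the scatter). The estimate for compound 4 is 300 nM, within 60 nM to 1500 nM.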

Compound 4, half-maximal inhibitory concentration: 2400 nM
Beside the measured number, compound 4's estimate is 8.0-fold (0.90 log units) below it; measured number outside the range, above it.
By their numbers in this assay, from the lowest: compound 2; then compound 3; then compound 4; then compound 1.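

In this assay, replacing 4-(trifluoromethyl)benzyl with 2-fluorobenzyl gives a 24-fold higher number from compound 2 to compound 4 (1.38 log units; beyond the scatter). This shows that the benzyl arm on the amine nitrogen in a ring is not a bystander: changing it alone, with the 3-cyanophenyl part kept, shifts the number by a large step. No measurement here gives a reason for this step.

The swap changes both the substituent and its printed ring position, and these two changes cannot be told apart here. A 4-fluorobenzyl or a plain benzyl arm would help to separate them.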